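Changing the amine tail on a shared stilbene-linked core

The source may hold more compounds than are shown below. What is called first, only, known or untested is meant among the compounds shown, and "the series" means these compounds.

All four compounds share one core, seen in compound 1 `COc1ccc(/C=C\c2cc(OC)c(OC)c(OC)c2)cc1OCc1ccc(CN[C@H](C(=O)O)[C@H](C)O)cc1`, and differ only in the group on a saturated chain carbon bound to an aromatic carbon. In a functional assay on MC-38 cells (Mus musculus) for antiproliferative activity, read by CCK-8 assay, with a stated time of 48 h (a lower number here means a stronger inhibitor, a higher number a weaker inhibitor), compound 1 gives > 10000 nM, which is a limit of the assay and not a number. Compound 2 `COc1ccc(/C=C\c2cc(OC)c(OC)c(OC)c2)cc1OCc1ccc(CN2C[C@H](O)C[C@@H]2C(=O)O)cc1` likewise gives > 10000 nM in this assay, again a limit. For the measured compounds named here, compound 3 `COc1ccc(/C=C\c2cc(OC)c(OC)c(OC)c2)cc1OCc1ccc(CN2CC[C@@H](C(=O)O)C2)cc1` is the only one with a number, giving 6300 nM in this assay, and so stands as the single fixed point among the values shown. As far as these compounds go, the two measured steps that lead to it are an at least 1.5-fold lower number from compound 1 to compound 3 (0.20 log units; that floor lies within the scatter) and an at least 1.5-fold lower number from compound 2 to compound 3 (0.20 log units; that floor lies within the scatter); both rest on the limit (the limit of > 10000 nM in this assay, at which 2 of the 3 values shown sit), so their true size is unknown and may be small. Compound 4 `COc1ccc(/C=C\c2cc(OC)c(OC)c(OC)c2)cc1OCc1ccc(CN2CCCCC2C(=O)NCCN)cc1` carries the change (2-((2-aminoethyl)carbamoyl)piperidin-1-yl in place of 3-carboxypyrrolidin-1-yl on a saturated chain carbon bound to an aromatic carbon). Two earlier changes of this tail moved the value by an amount that cannot be called large, so the step to compound 4 is expected to be modest, with a possible drift toward a weaker number: a 1.1-fold higher number from compound 3 to compound 4 (0.05 log units; within the scatter) is the estimate. Compound 4 is therefore expected to give about 7000 nM in this assay, between 2000 nM and 20000 nM.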

Compound 4, half-maximal inhibitory concentration: > 10000 nM
Compound 4: only a limit was reported; the forecaster's own chance of this, stated with the estimate: 35%; at least 1.4-fold (0.15 log units) between middle value and limit.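

Compound 4 is the first compound shown whose tail carries no carboxylic acid: its 2-((2-aminoethyl)carbamoyl)piperidin-1-yl group brings an amide, a primary amine and a six-membered ring in place of the five-membered ring of 3-carboxypyrrolidin-1-yl. In this assay, as far as these compounds go, this change gives an at least 1.5-fold higher number from compound 3 to compound 4 (0.20 log units; that floor lies within the scatter), so the exchange brings no measurable gain, while its true size stays unknown and may be small. The steps to compound 4 from compound 1 and from compound 2 cannot be read, and compound 3 remains the only compound with a number, all others sitting at a limit of the assay: the limit of > 10000 nM in this assay, at which 3 of the 4 values shown sit.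

Because the ring, the carboxylic acid and the aminoethyl chain all change together in this one step, the compounds shown cannot tell which of these parts matters, nor how far compound 4 truly lies from compound 3. A piperidine ring carrying a carboxylic acid, or a pyrrolidine ring carrying the same 2-aminoethyl amide, would separate the ring from the group it carries.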